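The source may hold more compounds than are shown below. What is called first, only, known or untested is meant among the compounds shown, and "the series" means these compounds.

Working notes on the series. In an assay for inhibition of kynurenine 3-monooxygenase (Homo sapiens), read by mass spectrometry, with a stated time of 1 h (on this read-out higher numbers stand for weaker inhibition and lower numbers for stronger inhibition), compound 1 `Cc1ccnc([C@@H](C)Oc2cc3oc(=O)n(CCC(=O)O)c3cc2Cl)c1` gives 3.98 nM, compound 2 `CCOc1cc2oc(=O)n(CCC(=O)O)c2cc1Cl` gives 5.01 nM, and compound 3 `COc1cc2oc(=O)n(CCC(=O)O)c2cc1Cl` gives 12.6 nM. Compound 3 therefore stands at the highest number of the three, with compound 2 nearest and compound 1 furthest from it. The not yet measured compound 4 `C[C@@H](Oc1cc2oc(=O)n(CCC(=O)O)c2cc1Cl)c1ncccn1` differs from compound 3 in one place: a group of 8 heavy atoms (6 carbon, 2 nitrogen; one six-membered aromatic ring with 2 hetero atoms) in place of one carbon atom, on an oxygen on an aromatic ring. Among the measured compounds shown here, two measured steps bear on this. Taking the methyl off the saturated chain carbon gave a 2.5-fold higher number from compound 2 to compound 3 (0.40 log units; beyond the scatter), while taking the 4-methylpyridin-2-yl off the same carbon gave a 1.3-fold higher number from compound 1 to compound 2 (0.10 log units; within the scatter). Reversing both together, compound 4 sits closest in build to compound 1, with a six-membered aromatic ring carrying two nitrogens in place of the 4-methylpyridin-2-yl. The expectation is therefore a drop in this assay of about a 2.8-fold lower number from compound 3 to compound 4 (0.45 log units; beyond the scatter), landing compound 4 near compound 1 and compound 2. For compound 4 the estimated value in this assay is 4.5 nM, with a range of 2 nM to 10 nM.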

Compound 4, half-maximal inhibitory concentration: 5.01 nM
Compound 4: middle estimate off by 1.1-fold (0.05 log units), on the low side; low and high end bracket the measured number.
By their numbers in this assay, from the lowest: compounds 1, 2 and 4 (each within the scatter of the next); then compound 3.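

In this assay, the group carrying pyrimidin-2-yl in place of the methyl on the oxygen gives a 2.5-fold lower number from compound 3 to compound 4 (0.40 log units; beyond the scatter), so this position accepts a six-membered aromatic ring with 2 hetero atoms on the saturated chain carbon without losing ground against the smaller group. Pyrimidin-2-yl in place of hydrogen gives no change at the digits printed from compound 2 to compound 4 (within the scatter), and pyrimidin-2-yl in place of 4-methylpyridin-2-yl gives a 1.3-fold higher number from compound 1 to compound 4 (0.10 log units; within the scatter), so among these three compounds neither adding this ring nor exchanging one ring for the other moves the number beyond the scatter. Nothing at hand explains why the number stays flat across these changes.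

The compounds shown leave open whether an amine or a carboxylic acid in place of pyrimidin-2-yl on the saturated chain carbon would hold the number at this level. They also leave open how the opposite configuration at the defined stereocentre would read.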